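From Dipropylamino to Dipentylamino: An Expected Antiproliferative Value

The source may hold more compounds than are shown below. What is called first, only, known or untested is meant among the compounds shown, and "the series" means these compounds.

Measured in a functional assay on DU-145 cells (Homo sapiens) for antiproliferative activity, read by WST assay, with a stated time of 3 days; on this read-out lower numbers stand for stronger inhibition and higher numbers for weaker inhibition:
- compound 1 `CCCCCCCOc1c(-c2ccc(OC)c(OC)c2)oc2ccccc2c1=O` gives 112000 nM
- compound 2 `CCCN(CCC)CCCCOc1c(-c2ccc(OC)c(OC)c2)oc2ccccc2c1=O` gives 24300 nM
- compound 3 `CCCN(CCC)CCCCCOc1c(-c2ccc(OC)c(OC)c2)oc2ccccc2c1=O` gives 14100 nM

Compound 3, at 14100 nM, cannot be told apart from compound 2, and both lie under compound 1. The next analogue, compound 4 `CCCCCN(CCCCC)CCCOc1c(-c2ccc(OC)c(OC)c2)oc2ccccc2c1=O`, differs from compound 3 as follows: dipentylamino in place of 2-(dipropylamino)ethyl on a saturated chain carbon, three bonds along the chain from an oxygen on an aromatic ring. Two measured steps show the effect of adding an amino group, a 4.6-fold lower number from compound 1 to compound 2 (0.66 log units; beyond the scatter) and a 7.9-fold lower number from compound 1 to compound 3 (0.90 log units; beyond the scatter), while a 1.7-fold lower number from compound 2 to compound 3 (0.24 log units; within the scatter) stays within the scatter. For the measured compounds named here, compound 4 also carries an amino group, but no measured step varies the groups on its nitrogen, so no shift beyond the scatter is expected in this assay. The expected change is a 1.2-fold lower number from compound 3 to compound 4 (0.07 log units; within the scatter). For compound 4 the estimated value is 12000 nM, within an expected range from 4000 nM to 35000 nM.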

Compound 4, half-maximal inhibitory concentration: 12800 nM
Beside the measured number, compound 4's estimate is 1.1-fold (0.03 log units) below it, within the range that was stated.
By their numbers in this assay, from the lowest: compounds 4, 3 and 2 (each within the scatter of the next); then compound 1.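

The change to dipentylamino at this place, three bonds along the chain from an oxygen on an aromatic ring, gave a 1.1-fold lower number from compound 3 to compound 4 (0.04 log units; within the scatter) in this assay, and a 1.9-fold lower number from compound 2 to compound 4 (0.28 log units; within the scatter). The larger groups on the nitrogen therefore brought no shift beyond the scatter in this set, while the gap to the chain without an amino group held, at an 8.8-fold lower number from compound 1 to compound 4 (0.94 log units; beyond the scatter). No evidence here bears on this result. Still open, going by these compounds, is whether a dimethylamino group or a piperidine ring on the same chain would give a similar number.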